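The compounds below may be only part of what the source reports. "The series", "measured", "known", "first", "only" and "open" are said of these compounds alone.

Measured in a functional assay on HEK293 cells for antagonist activity at proteinase-activated receptor 4 (Homo sapiens), read by FLIPR and calcium flux, with a stated time of 30 min; on this read-out lower numbers stand for stronger inhibition and higher numbers for weaker inhibition:
- compound 1 `COc1cc(OCc2cccc(CCc3ccccc3)c2)c2cc(-c3cn4nc(OC)sc4n3)oc2c1` gives 2.4 nM
- compound 2 `COc1nn2cc(-c3cc4c(OC)cccc4o3)nc2s1` gives 7.6 nM
- compound 3 `COc1cc(OCc2cccc(Oc3ccccc3)c2)c2cc(-c3cn4nc(OC)sc4n3)oc2c1` gives 1.2 nM

Among the measured compounds shown here, compound 3 holds the lowest of these three numbers, but the one measured step that reaches it, a 2.0-fold lower number from compound 1 to compound 3 (0.30 log units; within the scatter), lies within the scatter, so it cannot be ranked against compound 1; only compound 2 sits clearly apart, beyond the scatter. The unmeasured compound 4 `COc1cc(OCc2cccc(Sc3ccccc3)c2)c2cc(-c3cn4nc(OC)sc4n3)oc2c1` differs from compound 3 by phenylsulfanyl in place of phenoxy on an aromatic carbon. For the measured compounds named here, no measured pair exchanges the sulfur-linked group for the oxygen-linked one, so the only step that bears on it is the one just named, which was within the scatter. Compound 4 is therefore expected to show no step beyond the scatter in this assay, with a 1.3-fold higher number from compound 3 to compound 4 (0.10 log units; within the scatter) as the estimated shift. Compound 4 is estimated at 1.5 nM, within 0.5 nM to 5 nM.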

Compound 4, half-maximal inhibitory concentration: 0.89 nM
Beside the measured number, compound 4's estimate is 1.7-fold (0.23 log units) above it; the range from low to high includes it.
By their numbers in this assay, from the lowest: compounds 4, 3 and 1 (each within the scatter of the next, the first and the last beyond it); then compound 2.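

In this assay, among the compounds shown here, phenylsulfanyl in place of phenoxy on an aromatic carbon, meta to a large group, gives no step that stands clear of the scatter (a 1.3-fold lower number from compound 3 to compound 4 (0.13 log units; within the scatter)). Set against phenethyl at the same place, however, phenylsulfanyl gives the first step at this position that lies beyond the scatter, though it is modest (a 2.7-fold lower number from compound 1 to compound 4 (0.43 log units; beyond the scatter)). No measurement at hand accounts for either step. The compounds shown leave open whether a sulfonyl or an amine link in place of the sulfur would keep these numbers. They also leave open how a carboxylic acid on the outer phenyl ring would read.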